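The compounds below may be only part of what the source reports. "The series", "measured", "known", "first", "only" and "open" are said of these compounds alone.

Working notes on the series. In an ADME assay on MT4 cells (Homo sapiens) for cytotoxicity, read by MTT assay, with a stated time of 5 days (on this read-out lower numbers stand for higher toxicity in this test and higher numbers for lower toxicity in this test), compound 1 (`COc1cc2nc(Nc3ccc(C#N)cc3)nc(Nc3c(C)cc(/C=C/C#N)cc3F)c2cc1OC`) gives > 52000 nM as a limit of the assay and not a number. Compound 2 (`COc1cc2nc(SCC(=O)Nc3cccc(S(N)(=O)=O)c3)nc(Nc3c(Cl)cc(/C=C/C#N)cc3Cl)c2cc1OC`) gives > 194000 nM as a limit too. Among the compounds with values here, compound 3 (`COc1cc2nc(SCC(=O)Nc3ccc(S(N)(=O)=O)cc3)nc(Nc3c(Cl)cc(/C=C/C#N)cc3Cl)c2cc1OC`) gives 116000 nM and is the only compound so far with an actual number, so it is the sole numeric reference point for the series.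

Compound 4 (`COc1cc2nc(SCC(=O)Nc3ccc(Cl)cc3)nc(Nc3c(Cl)cc(/C=C/C#N)cc3Cl)c2cc1OC`) takes chloro in place of sulfamoyl on an aromatic carbon, para to a large group (chloro in place of sulfamoyl on an aromatic carbon) and is otherwise the same as compound 3. Within the data shown here, the one measured step on this ring is an at least 1.6-fold lower number from compound 2 to compound 3 (0.22 log units; that floor lies within the scatter) and it only moves the sulfamoyl, with a floor within the scatter. It therefore says little about removing that group. Compound 1 also lacks the sulfamoyl, but it differs in other places and offers only a limit.

With so little to go on, a moderate move toward a lower number in this assay is expected, and that direction is held loosely. The estimated change is a 2.6-fold lower number from compound 3 to compound 4 (0.41 log units; beyond the scatter) on this read-out. For compound 4 the expected value is 45000 nM (estimated range 12000 nM to 150000 nM), and a report of a limit alone remains possible.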

Compound 4, half-maximal cytotoxic concentration: 29500 nM
For compound 4 the middle estimate is 1.5-fold (0.18 log units) above the measured one, within the range that was stated.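

In this assay, the change at this position, para to a large group, now has a readable effect: chloro in place of sulfamoyl gives a 3.9-fold lower number from compound 3 to compound 4 (0.59 log units; beyond the scatter), whereas the earlier step on this ring only moved the sulfamoyl and its floor lay within the scatter. The comparison with the 3-sulfamoylphenyl analogue gives an at least 6.5-fold lower number from compound 2 to compound 4 (0.81 log units; beyond the scatter), so the 4-chlorophenyl group sits on the side of higher toxicity in this test relative to both sulfamoyl compounds. That second step is only a floor, since compound 2 gives a limit of the assay and not a number: the limit of > 194000 nM in this assay, at which 1 of the 4 values shown sits.

The compounds shown do not separate the departure of sulfamoyl from the arrival of chloro, so it remains open whether the lower number follows from losing the one group or gaining the other. As far as these compounds go, a plain hydrogen, an amine or a carboxylic acid at the same place on this ring would help to settle that, and whether the trend holds on other cores also remains open.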